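The source may report more compounds than this note shows. Statements on the series, on what has been measured and on what is new or still open speak of the compounds shown alone.

Compound 2 `Fc1ccccc1-c1cn2ccnc2c(-c2ccc3ncn(C4CCCCC4)c3c2)n1` has the upper of the two numbers in a functional assay on SNB-75 cells (Homo sapiens) for inhibition, read by sulforhodamine B assay, with a stated time of 48 h, tested at 10 uM (a lower number here means less inhibition, a higher number more inhibition at the concentration tested (going by the name of the read-out)), where compound 2 gives 29.7%, while compound 1 `Brc1cn2ccnc2c(-c2ccc3ncn(C4CCCCC4)c3c2)n1` gives 21.3%; the step of a number 8.4 percentage points higher from compound 1 to compound 2 (within the scatter) stays within the scatter. Compound 3 `c1csc(-c2cn3ccnc3c(-c3ccc4ncn(C5CCCCC5)c4c3)n2)c1` differs from compound 2 by thiophen-2-yl in place of 2-fluorophenyl on an aromatic carbon. Within the data shown here, no measured step exchanges one aromatic ring for another at this place, and the only step known, a number 8.4 percentage points higher from compound 1 to compound 2 (within the scatter), lay within the scatter, so no movement beyond the scatter is expected in this assay. Compound 3 is therefore estimated at 25%, between 10% and 40%. The expected step of a number 4.7 percentage points lower from compound 2 to compound 3 (within the scatter) is within the scatter.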

Compound 3, a percentage reported as inhibition, at one concentration (the size of the read-out at that concentration, not a potency): 8.13%
Compound 3: middle estimate off by 16.9 percentage points, on the high side; measured number outside the range, below it.
By their numbers in this assay, from the lowest: compound 3; then compounds 1 and 2 (each within the scatter of the next).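

Swapping one aromatic ring for another at this position is not a neutral change in this assay: the result is a number 21.6 percentage points lower from compound 2 to compound 3 (beyond the scatter) and is the first step here to clear the scatter. Thiophen-2-yl also compares poorly with a single bromo atom, giving a number 13.2 percentage points lower from compound 1 to compound 3 (beyond the scatter) and showing that an aromatic ring here does not by itself keep the number up. Nothing available explains why thiophen-2-yl and 2-fluorophenyl differ.

As far as these compounds go, how an unsubstituted phenyl, an amine or a carboxylic acid would behave at this position remains open.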